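The compounds below may be only part of what the source reports. "The series", "measured", "known", "first", "only" and "open" are said of these compounds alone.

Measured compounds:
- compound 1 `CC1=C(C(=O)OC(C(F)(F)F)C(F)(F)F)C(c2ccoc2)NC(=O)N1`, 1%
- compound 2 `CC1=C(C(=O)OC(C)C(F)(F)F)C(c2cccs2)NC(=O)N1`, 3%; 3% (2 entries)
- compound 3 `CC1=C(C(=O)OCC(F)(F)F)C(c2ccsc2)NC(=O)N1`, 1%

In an assay on HeLa cells for displacement of a labelled ligand from adenosine receptor A3 (Homo sapiens), read by radioligand binding, with a stated time of 180 min, tested at 1 uM (on this read-out higher numbers stand for more inhibition at the one concentration tested (going by the name of the read-out) and lower numbers for less inhibition), compound 3 gives 1%, level with compound 1 at the digits shown, and compound 2 sits within the same scatter. All three share a core and differ only in the ester chain and the five-membered aromatic ring with 1 hetero atom on the saturated ring carbon, and none shows meaningful displacement at this concentration.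

Compound 4 `CC1=C(C(=O)OCC(F)(F)F)C(c2cccs2)NC(=O)N1` has not been measured. Against compound 3 the change is thiophen-2-yl in place of thiophen-3-yl on a saturated ring carbon. Going by the values given here, no pair of measured compounds reports a step, so the expectation rests on the flat picture: no step beyond the scatter is expected, in either direction, and compound 4 is estimated at 2% (range -8% to 12%), a step of a number 1 percentage points higher from compound 3 to compound 4 (within the scatter).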

Compound 4, a percentage reported as inhibition, at one concentration (the size of the read-out at that concentration, not a potency): 1%
Compound 4: the middle estimate sits 1 percentage points above what was measured; measured number inside the range.
By their numbers in this assay, from the lowest: compounds 1, 3 and 4 (each within the scatter of the next).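

In this assay, going by these compounds alone, the first comparison that differs in only one place shows no change at the digits printed from compound 3 to compound 4 (within the scatter) for thiophen-2-yl in place of thiophen-3-yl on a saturated ring carbon. With this ester, moving the attachment point of the sulfur-containing ring therefore leaves the reading unmoved, although a reading this low offers little room to reveal a difference. No supporting data bear on this result.

Still open, as far as these compounds go, is whether a phenyl ring carrying an amine on that carbon, or a longer chain in the ester, would raise inhibition at all.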